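The compounds below may be only part of what the source reports. "The series", "measured", "known", "first", "only" and "open" are said of these compounds alone.

Compound 1 `CCCCCCCC/C=C\CCCCCCC(=O)c1ncc(-c2ccoc2)o1`: 610 nM
Compound 2 `CCCCCCCC/C=C\CCCCCCC(=O)c1ncc(-c2ccco2)o1`: 54 nM

In an assay on isolated protein for inhibition of Fatty-acid amide hydrolase 1 (Homo sapiens) (a lower number here means a stronger inhibitor, a higher number a weaker inhibitor), compound 2 holds the lowest of the two numbers. For the measured compounds named here, the only measured step, an 11-fold lower number from compound 1 to compound 2 (1.05 log units; beyond the scatter), shows that swapping the small aromatic ring on the shared core can shift the result strongly.

Compound 3 `CCCCCCCC/C=C\CCCCCCC(=O)c1ncc(-c2ccccn2)o1` is the next change: pyridin-2-yl in place of furan-2-yl on an aromatic carbon. Going by the values given here, no measured pair compares pyridin-2-yl with furan-2-yl, so the direction is uncertain, but that earlier step suggests a shift beyond the scatter is likely. Compound 3 is expected to give 20 nM (range 4 nM to 100 nM), an estimated step of a 2.7-fold lower number from compound 2 to compound 3 (0.43 log units; beyond the scatter).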

Compound 3, inhibition constant: 18 nM
Beside the measured number, compound 3's estimate is 1.1-fold (0.05 log units) above it, and the stated range covers the measured number.
By their numbers in this assay, from the lowest: compound 3; then compound 2; then compound 1.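

In this assay pyridin-2-yl brings a 3.0-fold lower number from compound 2 to compound 3 (0.48 log units; beyond the scatter) and a 34-fold lower number from compound 1 to compound 3 (1.53 log units; beyond the scatter) so the position next to the ring oxygen accepts a six-membered aromatic ring as well as a five-membered one. Here the larger ring gives the lowest number of the three compounds, so the furan rings do not mark the best this position can offer.

Still open, as far as these compounds go, is how phenyl, which has no ring nitrogen, or pyridin-4-yl, with its nitrogen elsewhere in the ring, would compare with pyridin-2-yl. No measurement at hand explains why the number falls with this ring change.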